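Same Methoxy-to-Nitro Swap, Now at a Different Ring Position

A few compounds are considered here, and "the series" means these few. Any claim that something is new, unique, unknown or untested is made for them only; others in the source may bear on it.

Three compounds share one core and differ only in the aromatic ring at the end of the chain: compound 1 `COc1ccccc1OCCCCCC/N=C(\NC#N)Nc1ccncc1`, compound 2 `N#CN/C(=N\CCCCCCOc1ccccc1[N+](=O)[O-])Nc1ccncc1` and compound 3 `COc1ccc(OCCCCCC/N=C(\NC#N)Nc2ccncc2)cc1`. In a functional assay on NCI-H460 cells (Homo sapiens) for antiproliferative activity (on this read-out lower numbers stand for stronger inhibition and higher numbers for weaker inhibition), compound 1 gives 21 nM, compound 2 gives 41 nM and compound 3 gives 37 nM. The difference between the first two is nitro in place of methoxy on an aromatic carbon, and this step gave a 2.0-fold higher number from compound 1 to compound 2 (0.29 log units; within the scatter). Compound 3 differs from compound 1 by 4-methoxyphenyl in place of 2-methoxyphenyl on an oxygen on a saturated carbon, with a 1.8-fold higher number from compound 1 to compound 3 (0.25 log units; within the scatter).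

Compound 4 `N#CN/C(=N\CCCCCCOc1ccc([N+](=O)[O-])cc1)Nc1ccncc1` has not yet been measured in this assay. It differs from compound 3 by nitro in place of methoxy on an aromatic carbon. This is the same kind of change as the earlier one, though not the same: there the group sat ortho to a large group, here it sits para to a large group. For compound 4 a step of a 1.8-fold higher number from compound 3 to compound 4 (0.24 log units; within the scatter) is expected, resting on the earlier step of a 2.0-fold higher number from compound 1 to compound 2 (0.29 log units; within the scatter). Compound 4 is therefore estimated at 65 nM, expected to fall between 30 nM and 150 nM.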

Compound 4, half-maximal inhibitory concentration: 590 nM
Compound 4: the middle estimate sits 9.1-fold (0.96 log units) below what was measured; measured number above the stated range.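

In this assay, the change from methoxy to nitro did not keep its size when carried from one core to the other: the same change on two cores in this assay, a 2.0-fold higher number (0.29 log units; within the scatter) from compound 1 to compound 2 and a 16-fold higher number (1.20 log units; beyond the scatter) from compound 3 to compound 4, 8.2-fold (0.91 log units) apart, beyond the scatter of two such steps. Compound 4 also stands apart from the other two compounds, with a 14-fold higher number from compound 2 to compound 4 (1.16 log units; beyond the scatter) and a 28-fold higher number from compound 1 to compound 4 (1.45 log units; beyond the scatter), while its direct step from the methoxy analogue is a 16-fold higher number from compound 3 to compound 4 (1.20 log units; beyond the scatter). So, among these four compounds, the effect of this change depends on where it is made, with a nitro group para to a large group costing far more than the 2-nitrophenyl case suggested, but two pairs do not show why the steps differ, nor do they give a rule for any other core.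

From the compounds shown here alone, it remains open whether this large step is specific to nitro or would also appear with another group in the same place, such as a nitrile or a chlorine atom. The compounds shown also leave open whether the gap between the two steps would persist with a shorter chain.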